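Working notes: step from compound 2 to compound 3

The source may report more compounds than this note shows. Statements on the series, on what has been measured and on what is new or still open speak of the compounds shown alone.

Measured so far:
compound 1 `CC(C)=CCn1c(CN2CCN(C(=O)C3CC3)CC2)nc2ccccc21`: 74.3%
compound 2 `COc1cccc(Cn2c(CN3CCN(C(=O)C4CC4)CC3)nc3ccccc32)c1`: 44.4%

In an assay on isolated protein for inhibition of aldehyde dehydrogenase 1A1 (Homo sapiens), read by spectrophotometry, tested at 10 uM (on this read-out lower numbers stand for less inhibition and higher numbers for more inhibition at the one concentration tested (going by the name of the read-out)), compound 1 gives 74.3%, and compound 2 gives 44.4%, the lower of the two numbers. Compound 3 `O=C(C1CC1)N1CCN(Cc2nc3ccccc3n2CC2CC2)CC1` differs from compound 2 by cyclopropyl in place of 3-methoxyphenyl on a saturated chain carbon bound to an aromatic nitrogen. For the measured compounds named here, the one step that bears on this is a number 29.9 percentage points lower from compound 1 to compound 2 (beyond the scatter), where the 3-methoxyphenyl entered; its removal here is expected to recover part of that loss, so a rise of a number 17.6 percentage points higher from compound 2 to compound 3 (beyond the scatter) is expected in this assay. Compound 3 is estimated at 62%, within 38% to 85%.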

Compound 3, a percentage reported as inhibition, at one concentration (the size of the read-out at that concentration, not a potency): 21.2%
Compound 3: the middle estimate sits 40.8 percentage points above what was measured; the whole stated range lies above it.
By their numbers in this assay, from the lowest: compound 3; then compound 2; then compound 1.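

Cyclopropyl in place of 3-methoxyphenyl gives a number 23.2 percentage points lower from compound 2 to compound 3 (beyond the scatter) in this assay and so does not recover the loss seen with the aromatic group. Against the 2-methylprop-1-en-1-yl, cyclopropyl gives a number 53.1 percentage points lower from compound 1 to compound 3 (beyond the scatter) and this makes the position more sensitive than the first pair showed, with the order not following the smaller group upward. No supporting measurement accounts for this order.

The compounds shown leave open whether the high number of compound 1 needs the 2-methylprop-1-en-1-yl itself. A longer saturated chain or an amine at this position could help settle that.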